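A few compounds are considered here, and "the series" means these few. Any claim that something is new, unique, unknown or untested is made for them only; others in the source may bear on it.

Working notes on the series.

Three compounds share one core and carry a pyrrolidin-1-yl tail on the propoxy chain. Compound 1 `COc1cc2c(Oc3ccc(NC(=O)NN4C(=O)CSC4c4c(F)cccc4F)c(Cl)c3)ccnc2cc1OCCCN1CCCC1` gives 960 nM in a functional assay on A549 cells (Homo sapiens) for antiproliferative activity, read by MTT assay, with a stated time of 72 h; on this read-out lower numbers stand for stronger inhibition and higher numbers for weaker inhibition. Compound 2 `COc1cc2c(Oc3ccc(NC(=O)NN4C(=O)CSC4c4c(F)cccc4F)c4ccccc34)ccnc2cc1OCCCN1CCCC1` gives 2360 nM in this assay. Compound 3 `COc1cc2c(Oc3c(F)cc(NC(=O)NN4C(=O)CSC4c4c(F)cccc4F)cc3F)ccnc2cc1OCCCN1CCCC1` gives 560 nM in this assay, the lowest of the three numbers; its gap to compound 1 lies within the scatter, and only its gap to compound 2 lies beyond it, so compound 3 cannot be called the strongest of the set.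

Compound 4 `COc1cc2c(Oc3c(F)cc(NC(=O)NN4C(=O)CSC4c4c(F)cccc4F)cc3F)ccnc2cc1OCCCN1CCN(C)CC1` is not yet measured. It differs from compound 3 in one place: 4-methylpiperazin-1-yl in place of pyrrolidin-1-yl on a saturated chain carbon, three bonds along the chain from an oxygen on an aromatic ring. Among the measured compounds shown here, no measured pair in the set shows this exchange, so the step has to be guessed from the position of the change alone, far out on the chain from the rest of the molecule. No step beyond the scatter is expected from compound 3 to compound 4 in this assay; the estimated step is a 1.1-fold higher number from compound 3 to compound 4 (0.03 log units; within the scatter). For compound 4 the expected value in this assay is 600 nM, with a range from 250 nM to 1500 nM.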

Compound 4, half-maximal inhibitory concentration: 510 nM
Estimate against measurement, compound 4: 1.2-fold (0.07 log units) above; measured number inside the range.
By their numbers in this assay, from the lowest: compounds 4, 3 and 1 (each within the scatter of the next); then compound 2.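

In this assay, the step for 4-methylpiperazin-1-yl in place of pyrrolidin-1-yl reads a 1.1-fold lower number from compound 3 to compound 4 (0.04 log units; within the scatter), which lies within the scatter. Among the compounds shown here, this is the first reading at this position, on a saturated chain carbon, three bonds along the chain from an oxygen on an aromatic ring, and it shows that this exchange leaves the number unresolved from that of the pyrrolidin-1-yl compound, for this one pair. Nothing at hand gives a reason for this result.

On these data alone, whether a morpholin-4-yl group, a dimethylamino group or a longer chain would also leave the number unchanged remains open. Also open, as far as these compounds go, is whether the same exchange would give a similar step on the cores of compound 1 and compound 2.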